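Removing One Methoxy Group From an Inactive Series

A few compounds are considered here, and "the series" means these few. Any claim that something is new, unique, unknown or untested is made for them only; others in the source may bear on it.

Measured so far:
compound 1 `COc1cc(-c2cc(/C=C/C(=O)c3ccc(N)cc3)[nH]n2)cc(OC)c1OC`, in a functional assay on SF-539 cells (Homo sapiens) for cytotoxicity, read by sulforhodamine B assay, with a stated time of 48 h, tested at 0.1 uM (on this read-out lower numbers stand for a stronger effect and higher numbers for a weaker effect at the one concentration tested), compound 1 gives 99%
compound 2 `COc1ccc(C(=O)/C=C/c2cc(-c3cc(OC)c(OC)c(OC)c3)n[nH]2)cc1OC`, in this assay compound 2 gives 98%
compound 3 `COc1ccc(C(=O)/C=C/c2cc(-c3cc(OC)c(OC)c(OC)c3)n[nH]2)cc1`, in this assay compound 3 gives 99%

All three numbers sit close together, and none of the steps between them leaves the scatter. From compound 2 to compound 3 the change is hydrogen in place of methoxy on an aromatic carbon, and it gave a number 1 percentage points higher from compound 2 to compound 3 (within the scatter). The step from compound 1 to compound 3 is no change at the digits printed from compound 1 to compound 3 (within the scatter), and from compound 1 to compound 2 it is a number 1 percentage points lower from compound 1 to compound 2 (within the scatter).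

Compound 4 `COc1ccc(-c2cc(/C=C/C(=O)c3ccc(N)cc3)[nH]n2)cc1OC` has not yet been measured. It differs from compound 1 by hydrogen in place of methoxy on an aromatic carbon. The two cores differ by 4-aminophenyl in place of 3,4-dimethoxyphenyl on a carbonyl carbon. The place of the change in compound 4 is additionally described as meta to a methoxy group, so the change from compound 1 to compound 4 is the same kind of change as that from compound 2 to compound 3, not the same.

Because the earlier step of a number 1 percentage points higher from compound 2 to compound 3 (within the scatter) stayed within the scatter, the corresponding step for compound 4 is expected to be a number 1 percentage points lower from compound 1 to compound 4 (within the scatter). Compound 4 is therefore estimated to give 98% in this assay, with a range from 90% to 103%.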

Compound 4, a percentage reported as activity, at one concentration (the size of the read-out at that concentration, not a potency): 97%
Beside the measured number, compound 4's estimate is 1 percentage points above it, and the stated range covers the measured number.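

Taking the methoxy group off the core of compound 1 gave a number 2 percentage points lower from compound 1 to compound 4 (within the scatter) in this assay, so on this core too the replacement by hydrogen produced no step that can be told from the scatter. Set beside the same change on the other core, the two steps do not differ: the same change on two cores in this assay, a number 1 percentage points higher (within the scatter) from compound 2 to compound 3 and a number 2 percentage points lower (within the scatter) from compound 1 to compound 4, 3 percentage points apart, within the scatter of two such steps. Among the compounds shown here, this agreement shows only that the change left the read-out within the scatter on both cores at the one concentration tested; it does not show that a real effect of this change carries from one core to another, as neither core displays such an effect to carry.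

The compounds shown leave open whether any other group in the place of this methoxy group, such as a hydroxyl group, a chlorine atom or an amine, would move the number beyond the scatter. They also leave open whether the two cores would still agree once a step of that size appeared.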